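Two Cyanoguanidine Esters and an Untested Third

The source may report more compounds than this note shows. Statements on the series, on what has been measured and on what is new or still open speak of the compounds shown alone.

Of the compounds shown here, two have been tested so far. Compound 1 `CC1=C(C(=O)OC(C)C)C(c2ccsc2)N/C(=N/C#N)N1` carries a thiophene ring and an isopropyl ester; in an assay on cells for displacement of a labelled ligand from adenosine receptor A1 (Homo sapiens), with a stated time of 60 min, tested at 1 uM (a higher number here means more inhibition at the concentration tested (going by the name of the read-out), a lower number less inhibition), compound 1 gives 11%. Compound 2 `CCOC(=O)C1=C(C)N/C(=N\C#N)NC1c1ccccc1` carries a phenyl ring and an ethyl ester; in this assay compound 2 gives 18%. The gap between these two values is within the scatter of repeated measurements, so compound 2 cannot be set apart from compound 1 on these numbers; both sit at the low end of the scale. Among the measured compounds shown here, no pair of measured compounds differs in only one place, so no single step has been measured.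

Compound 3 `CC1=C(C(=O)OC(C)C)C(c2ccccc2)N/C(=N/C#N)N1` is the untested compound. It differs from compound 2 in one spot: methyl in place of hydrogen on a saturated chain carbon bound to an oxygen next to a carbonyl group and a saturated chain carbon. Read one bond further out, the change is ethoxycarbonyl to isopropoxycarbonyl. For the measured compounds named here, with no measured step to lean on, the expectation for this change in this assay is no movement beyond the scatter, perhaps a slight drift downward. Compound 3 is expected to give 13%, within a range from 2% to 28%, an estimated step of a number 5 percentage points lower from compound 2 to compound 3 (within the scatter).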

Compound 3, a percentage reported as inhibition, at one concentration (the size of the read-out at that concentration, not a potency): 20%
Beside the measured number, compound 3's estimate is 7 percentage points below it, within the range that was stated.
By their numbers in this assay, from the lowest: compounds 1, 2 and 3 (each within the scatter of the next).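

Going from ethoxycarbonyl to isopropoxycarbonyl gives the first measured single step at this ester position. In this assay it reads a number 2 percentage points higher from compound 2 to compound 3 (within the scatter), so the added methyl on the saturated chain carbon bound to an oxygen produces no change that can be told apart from ordinary repeat variation. The second single step, phenyl in place of thiophen-3-yl on a saturated ring carbon, reads a number 9 percentage points higher from compound 1 to compound 3 (within the scatter), so this ring swap cannot be told apart from that variation either, and no measurement here offers any explanation of either result.

These three compounds leave open whether a bigger change at either place would shift the number beyond the scatter, such as a carboxylic acid or a longer chain in place of the ester, or a pyridine ring in place of phenyl. They also leave open how potent any of the compounds is, since a percentage read at a single concentration is not a potency.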